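The source may report more compounds than this note shows. Statements on the series, on what has been measured and on what is new or still open speak of the compounds shown alone.

Within the data shown here, compound 1 `CN(C)CCn1cnnc1-c1cc(Oc2ccc(NC(=O)Nc3ccc(Cl)cc3Cl)cc2F)ccn1` is the one compound here with a plain number: in an ADME assay on WI-38 cells (Homo sapiens) for cytotoxicity, read by MTT assay, with a stated time of 72 h (a higher number here means a weaker inhibitor, a lower number a stronger inhibitor), compound 1 gives 10400 nM. Among the measured compounds shown here, compound 2 `CCN(CC)CCn1cnnc1-c1cc(Oc2ccc(NC(=O)Nc3ccc(F)c(F)c3)cc2F)ccn1` differs from compound 1 in two places, so no single step joins them. In this assay compound 2 reaches only a limit, > 50000 nM, not a measured number. This is the situation of the limit of > 50000 nM in this assay, at which 1 of the 2 values shown sits. Compound 3 `CCN(CC)CCn1cnnc1-c1cc(Oc2ccc(NC(=O)Nc3ccc(Cl)cc3Cl)cc2F)ccn1` is made from compound 2 by one change, (2,4-dichlorophenyl in place of 3,4-difluorophenyl on an amide-type nitrogen). For the measured compounds named here, no measured pair shows this change on its own, so nothing here gives its size directly. What can be said is that compound 3 and compound 1 both carry the 2,4-dichlorophenyl group, and compound 1 gives a real number in this assay of 10400 nM, whereas compound 2 with the 3,4-difluorophenyl group does not. The step from compound 2 to compound 3 is therefore expected to run toward a stronger inhibitor, by about an at least 2.5-fold lower number from compound 2 to compound 3 (0.39 log units; beyond the scatter), though a second limit remains quite possible. Compound 3 is expected to give roughly 20000 nM, most likely between 6000 nM and 80000 nM.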

Compound 3, half-maximal inhibitory concentration: 4280 nM
The estimate for compound 3 lay 4.7-fold (0.67 log units) above the measured number, outside the stated range (below it).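

In this assay, 2,4-dichlorophenyl in place of 3,4-difluorophenyl on an amide-type nitrogen gives an at least 11-fold lower number from compound 2 to compound 3 (1.06 log units; beyond the scatter), so this position can change the read-out by a large amount. That size is only a lower bound, because compound 2 stands at a limit of the assay rather than at a measured number: the limit of > 50000 nM in this assay, at which 1 of the 3 values shown sits.

The amine on the chain matters too, though less: diethylamino in place of dimethylamino on a saturated chain carbon, two bonds along the chain from an aromatic nitrogen, gives a 2.4-fold lower number from compound 1 to compound 3 (0.39 log units; beyond the scatter), a modest step that is still beyond the scatter, with the 2,4-dichlorophenyl group the same in both compounds.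

The compounds shown leave open whether the large step comes from having chlorine rather than fluorine or from where the halogens sit on the ring, which a 3,4-dichlorophenyl or a 2,4-difluorophenyl group at the same nitrogen would help to separate. They also leave open whether the number keeps falling with other amines on the chain, such as dipropylamino, pyrrolidine or morpholine in place of diethylamino.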